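Notes on the acetamide heteroaryl swap, compound 3 to compound 4

The source may hold more compounds than are shown below. What is called first, only, known or untested is meant among the compounds shown, and "the series" means these compounds.

Measured so far in an assay on blood for inhibition of C-X-C chemokine receptor type 3 (Homo sapiens), with a stated time of 30 min; a higher number here means a weaker inhibitor, a lower number a stronger inhibitor:
compound 1 `CCOc1ncc(-c2nc(C(F)(F)F)sc2N2CCN(C(=O)Cn3ccc4cccnc43)[C@H](C)C2)cn1` gives 47 nM
compound 2 `CCOc1ncc(-c2nc(C(F)(F)F)sc2N2CCN(C(=O)Cn3ncc4cccnc43)[C@H](C)C2)cn1` gives 372 nM
compound 3 `CCOc1ncc(-c2nc(C(F)(F)F)sc2N2CCN(C(=O)Cn3nc(C)nc3C)[C@H](C)C2)cn1` gives 364 nM

Compound 3 stands second highest of the three numbers in this assay. Nearest: a 1.0-fold lower number from compound 2 to compound 3 (0.01 log units; within the scatter), so these two cannot be told apart. Furthest: a 7.7-fold higher number from compound 1 to compound 3 (0.89 log units; beyond the scatter). The remaining step, a 7.9-fold higher number from compound 1 to compound 2 (0.90 log units; beyond the scatter), is of the same size, so both changes away from the group of compound 1 cost alike.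

Compound 4 `CCOc1ncc(-c2nc(C(F)(F)F)sc2N2CCN(C(=O)Cn3ccc(C(F)(F)F)n3)[C@H](C)C2)cn1` differs from compound 3 only at the group on the saturated chain carbon bound to the carbonyl carbon: 3-(trifluoromethyl)-1H-pyrazol-1-yl in place of 3,5-dimethyl-1H-1,2,4-triazol-1-yl on a saturated chain carbon bound to a carbonyl carbon. For the measured compounds named here, no measured step covers a trifluoromethyl on a ring at this place, so the bearing is indirect. The step from compound 2 to compound 3 shows that a single five-membered ring here holds the level of the larger group of compound 2; the step from compound 1 to compound 3 shows that only the group of compound 1 stands apart. A different five-membered ring is therefore expected to stay near compound 3, with a step of at most modest size in either direction and none that can be called beyond the scatter with confidence. Compound 4 is expected at 250 nM, range 80 nM to 800 nM. This estimate means an expected step of a 1.5-fold lower number from compound 3 to compound 4 (0.16 log units; within the scatter).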

Compound 4, half-maximal inhibitory concentration: 90 nM
Compound 4: the middle estimate sits 2.8-fold (0.44 log units) above what was measured; low and high end bracket the measured number.
By their numbers in this assay, from the lowest: compounds 1 and 4 (each within the scatter of the next); then compounds 3 and 2 (each within the scatter of the next).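

In this assay, a single five-membered ring on a saturated chain carbon bound to a carbonyl carbon is not tied to the level of compound 3: 3-(trifluoromethyl)-1H-pyrazol-1-yl in place of 3,5-dimethyl-1H-1,2,4-triazol-1-yl gives a step beyond the scatter (a 4.0-fold lower number from compound 3 to compound 4 (0.61 log units; beyond the scatter)), and the step against the two-ring group of compound 2, which has the same heavy-atom count, is of like size (a 4.1-fold lower number from compound 2 to compound 4 (0.62 log units; beyond the scatter)). For the compounds shown here, the group of compound 1 therefore no longer stands alone, since the single ring of compound 4 cannot be told apart from it (a 1.9-fold higher number from compound 1 to compound 4 (0.28 log units; within the scatter)), while compound 3, also with a single ring, stays apart from both, so ring count alone does not set the level here. Nothing available bears on the cause of these steps.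

Ring and substituents change together from compound 3 to compound 4, so the shares of the trifluoromethyl and of the pyrazole in the step remain unseparated. The compounds shown leave open whether a methyl or a nitrile in place of the trifluoromethyl on the same pyrazole, or a trifluoromethyl on the 1,2,4-triazole, would hold the level of compound 4.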